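Hydroxy for Ethyl: What to Expect of Compound 4

The source may hold more compounds than are shown below. What is called first, only, known or untested is meant among the compounds shown, and "the series" means these compounds.

Three measured compounds share one core and differ only in the group on the saturated chain carbon bound to an amide-type nitrogen and a carbonyl carbon. In a functional assay on the whole organism (Tail, strain ICR) with Mus musculus as the target, in the tail flick test, with a stated time of 120 min, at a dose of 25 umol/kg by the oral route (a higher number here means a stronger effect of the compound at the dose given, a lower number a weaker effect), compound 1 `O=C(CN(c1ncnc2c1ncn2C1CCCCO1)C1CC1)N[C@@H](CCC(=O)OCc1ccccc1)C(=O)OCc1ccccc1` gives 20.7%, compound 2 `O=C(CN(c1ncnc2c1ncn2C1CCCCO1)C1CC1)NCC(=O)OCc1ccccc1` gives 17.2%, and compound 3 `CC[C@H](C)[C@H](NC(=O)CN(c1ncnc2c1ncn2C1CCCCO1)C1CC1)C(=O)OCc1ccccc1` gives 20.4%. Compound 3 thus stands second highest of the three numbers, but every gap around it is small: a number 0.3 percentage points lower from compound 1 to compound 3 (within the scatter) and a number 3.2 percentage points higher from compound 2 to compound 3 (within the scatter), just as a number 3.5 percentage points lower from compound 1 to compound 2 (within the scatter). Compound 4 `C[C@@H](O)[C@H](NC(=O)CN(c1ncnc2c1ncn2C1CCCCO1)C1CC1)C(=O)OCc1ccccc1` has not yet been measured in this assay. It differs from compound 3 by hydroxy in place of ethyl on a saturated chain carbon bound to two saturated chain carbons; cut one bond further out, the same difference reads sec-butyl to 1-hydroxyethyl. All three measured steps vary the same place in the molecule, and each stayed within the scatter, so the data give no sign that a change at this place moves the number beyond it. Exchanging hydrogen, sec-butyl and 2-(benzyloxycarbonyl)ethyl left this assay essentially unmoved, and a hydroxy entering in place of ethyl is expected to do likewise. The estimate for compound 4 is therefore 19%, with a range from 9% to 30%. The expected step is a number 1.4 percentage points lower from compound 3 to compound 4 (within the scatter).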

Compound 4, a percentage reported as activity, at one dose (the size of the read-out at that dose, not a potency): 10.9%
Compound 4: the middle estimate sits 8.1 percentage points above what was measured; the range from low to high includes it.
By their numbers in this assay, from the lowest: compounds 4, 2, 3 and 1 (each within the scatter of the next).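

Within the data shown here, the exchange of ethyl for hydroxy, which brings one hydrogen-bond donor and one hydrogen-bond acceptor where ethyl has none, gives a number 9.5 percentage points lower from compound 3 to compound 4 (within the scatter), the first step at this place to come close to the edge of the usual scatter without leaving it. Measured against the two other side chains, 1-hydroxyethyl gives a number 6.3 percentage points lower from compound 2 to compound 4 (within the scatter) when it replaces hydrogen and a number 9.8 percentage points lower from compound 1 to compound 4 (within the scatter) when it replaces 2-(benzyloxycarbonyl)ethyl, so all three new steps point the same way, though none can be read as a real loss of effect. The four compounds therefore still show no change at this place that clearly moves the number, and no accompanying measurement bears on the result.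

On these data alone, whether an amine or a carboxylic acid on this saturated chain carbon, or a longer chain ending in hydroxy, would carry the number beyond the scatter remains open. So does whether the small steps seen in this assay would hold with the benzyl ester replaced by a free carboxylic acid.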